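Inversion at the side-chain carbon of compound 2

This account rests on a few compounds, and the source may have more. Where it says the series, first, only, none or still open, it means among the compounds named here.

Compound 2 `C[C@@H](O[C@H]1CCCN[C@H]1c1ccccc1)c1cc(Cl)cc(Cl)c1` stands at the low end of the three measurements in a functional assay on microsomes from liver for antagonist activity at Substance-P receptor (Rattus norvegicus) (on this read-out lower numbers stand for stronger inhibition and higher numbers for weaker inhibition), giving 0.91 nM; compound 3 `C[C@H](O[C@H]1CCCN[C@H]1c1ccccc1)c1cc(C(F)(F)F)cc(C(F)(F)F)c1` gives 87 nM and compound 1 `c1ccc(CO[C@H]2CCCN[C@H]2c2ccccc2)cc1` gives 160 nM, both well beyond the scatter from compound 2. Compound 4 `C[C@H](O[C@H]1CCCN[C@H]1c1ccccc1)c1cc(Cl)cc(Cl)c1` keeps every atom and bond of compound 2: the two compounds have the same atoms and bonds and differ only in configuration as drawn: 1 of 3 stereo elements differ; a stereocentre at a saturated chain carbon is drawn R in compound 2 and S in compound 4. For the measured compounds named here, no pair of measured compounds differs by such an inversion alone, so the size of the step rests on the spread of the three numbers rather than on a directly comparable case. Compound 2 occupies a far lower position than either other compound, which suggests that a change at this stereocentre is more likely to move the number upward, toward weaker inhibition, than to improve it. Compound 4 is therefore expected to give 60 nM in this assay, within 8 nM to 400 nM, an estimated step of a 66-fold higher number from compound 2 to compound 4 (1.82 log units; beyond the scatter) that is expected because compound 2 gives 0.91 nM and sits apart from the others.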

Compound 4, half-maximal inhibitory concentration: 85 nM
Compound 4: the middle estimate sits 1.4-fold (0.15 log units) below what was measured, within the range that was stated.
By their numbers in this assay, from the lowest: compound 2; then compounds 4, 3 and 1 (each within the scatter of the next).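

For the compounds shown here, the pair of compound 2 and compound 4 isolates a single stereocentre, and in this assay it gives a 93-fold higher number from compound 2 to compound 4 (1.97 log units; beyond the scatter), a large step that the earlier compounds, which differ in more than one place, could not show. This step can be assigned to the inversion at the saturated chain carbon alone, because no atom or bond enters or leaves: the fact that compounds 2 and 4 differ only in the configuration as drawn. The configuration at this carbon is therefore a strong determinant of the number in this series, with the R drawing in compound 2 giving the far stronger inhibition.

On these data alone, whether the inversion moves the number as far with trifluoromethyl groups in place of the chlorine atoms stays open. Also open, as far as these compounds go, are how an ethyl or a hydroxymethyl group in place of the methyl at this carbon would read, and what inversion at either of the other two stereocentres would do.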